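The source may report more compounds than this note shows. Statements on the series, on what has been measured and on what is new or still open speak of the compounds shown alone.

In a functional assay on MDA-MB-231 cells (Homo sapiens) for inhibition, read by CCK-8 assay, with a stated time of 48 h (on this read-out lower numbers stand for stronger inhibition of growth and higher numbers for weaker inhibition of growth), compound 3 `Cc1ccccc1Nc1nc(NC2CCCCC2)ncc1Cl` reaches only a limit, > 100000 nM. Compound 2 `Cc1ccccc1Nc1nc(NC2CC2)ncc1Cl` also reaches only a limit, > 100000 nM. Compound 1 `Cc1ccccc1Nc1nc(Nc2cccnc2)ncc1Cl`, with pyridin-3-yl on the same nitrogen, gives a true number, 41200 nM. Compound 4 `Cc1ccccc1Nc1nc(Nc2ccccc2)ncc1Cl` puts phenyl in place of cyclohexyl on a nitrogen on an aromatic ring. The nearest guides are an at least 2.4-fold higher number from compound 1 to compound 3 (0.38 log units; beyond the scatter) and an at least 2.4-fold higher number from compound 1 to compound 2 (0.38 log units; beyond the scatter), each leaving an aromatic ring for a non-aromatic one. Both sizes are minimums, set by the limit of > 100000 nM in this assay, at which 2 of the 3 values shown sit. Returning to an aromatic ring should therefore reverse that change, giving a step of at least modest size toward stronger inhibition. The expected move is an at least 2.8-fold lower number from compound 3 to compound 4 (0.45 log units; beyond the scatter). For compound 4 the estimate is 35000 nM, with a range of 10000 nM to 100000 nM.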

Compound 4, concentration for 50% growth inhibition: > 100000 nM
Compound 4: only a limit was reported (the forecaster's own chance of this, stated with the estimate: 20%); middle value at least 2.8-fold (0.45 log units) away from the limit.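

Having an aromatic ring on this nitrogen is not enough in this assay: with phenyl in place of pyridin-3-yl there is an at least 2.4-fold higher number from compound 1 to compound 4 (0.38 log units; beyond the scatter). Among the compounds shown, only the pyridin-3-yl of compound 1 gives a true number, while compound 4 reads as a limit, like compound 2 and compound 3. The steps among those three cannot be read, because both ends of each are limits: the limit of > 100000 nM in this assay, at which 3 of the 4 values shown sit.

On these data alone, how compound 2, compound 3 and compound 4 truly rank stays open. Also open, as far as these compounds go, is whether pyridin-4-yl, or a phenyl carrying an amine, on this nitrogen would give a lower number than compound 1.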